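This account rests on a few compounds, and the source may have more. Where it says the series, first, only, none or still open, it means among the compounds named here.

Measured so far:
- compound 1, `CC[C@@H](Nc1c(C#N)c(-c2ccc(-c3ccc(F)cc3)cc2)nc2cnccc12)C(N)=O`: 2.7
- compound 2, `CC[C@@H](Nc1c(C#N)c(-c2ccc(-c3ccc(Cl)cc3)cc2)nc2cnccc12)C(N)=O`: 3.1
- compound 3, `CC[C@@H](Nc1c(C#N)c(-c2ccc(-c3ccccc3C(C)C)cc2)nc2cnccc12)C(N)=O`: not yet measured

In a physicochemical assay for lipophilicity, read by HPLC, at pH 7.5 (a higher number here means a more lipophilic compound, a lower number a more polar compound), compound 1 gives 2.7 and compound 2 gives 3.1. For the measured compounds named here, the single measured step, a number 0.40 log units higher from compound 1 to compound 2 (beyond the scatter), leaves compound 2 as the higher of the two. Compound 3 differs from compound 2 in one place: 2-isopropylphenyl in place of 4-chlorophenyl on an aromatic carbon. Going by the values given here, that step from fluoro to chloro is the only guide, and the present change is larger, swapping a seven-heavy-atom group for one of nine carbons. A clear upward step is therefore expected, a number 0.80 log units higher from compound 2 to compound 3 (beyond the scatter), and compound 3 is estimated at 3.9, within 3.4 to 4.4.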

Compound 3, distribution coefficient: 3.5
The estimate for compound 3 lay 0.40 log units above the measured number; the measured number falls inside the stated range.
By their numbers in this assay, from the lowest: compound 1; then compound 2; then compound 3.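

In this assay, this position also responds to replacing the whole group, not only to changing one halogen: the 2-isopropylphenyl group gives a number 0.40 log units higher from compound 2 to compound 3 (beyond the scatter), and against the fluoro compound it gives a number 0.80 log units higher from compound 1 to compound 3 (beyond the scatter). The step from 4-chlorophenyl, with 7 heavy atoms, to 2-isopropylphenyl, with 9, matches in size the halogen step, a number 0.40 log units higher from compound 1 to compound 2 (beyond the scatter). Nothing available explains why these steps have this size. On these data alone, what an amine or a carboxylic acid in this place would do to the number remains open.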